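The source may report more compounds than this note shows. Statements on the series, on what has been measured and on what is new or still open speak of the compounds shown alone.

Compound 1 `CO/N=C(\C#N)C(=O)NCC1=NOC(C(C)(C)C)C1` gives in a functional assay on MDBK cells (Bos taurus) for cytotoxicity (a lower number here means that less compound is tolerated, a higher number that more compound is tolerated), the value > 100 ug/mL, a limit of the assay rather than a number.
Compound 2 `CCO/N=C(\C#N)C(=O)NCC1=NOC(C(C)(C)C)C1` gives in this assay the value > 100 ug/mL, again a limit.
Compound 3 `C=CCO/N=C(\C)C(=O)NCC1=NOC(C(C)(C)C)C1` gives in this assay the value > 100 ug/mL, also a limit.

From compound 1 to compound 2 the change is methyl in place of hydrogen on a saturated chain carbon bound to an oxygen on an unsaturated carbon, and the step is a step that the two limits leave unreadable from compound 1 to compound 2. Compound 4 `C=CCO/N=C(\CC)C(=O)NCC1=NOC(C(C)(C)C)C1` has not yet been measured; it differs from compound 3 by methyl in place of hydrogen on a saturated chain carbon bound to a carbon with a double bond to nitrogen, the same kind of change, though here the place is a carbon with a double bond to nitrogen rather than an oxygen on an unsaturated carbon. How the core of compound 1 and the core of compound 3 differ is not broken down here. Among the compounds with values here, because the limit of > 100 ug/mL in this assay, at which 3 of the 3 values shown sit, every value so far sits at the same limit, the step from compound 3 to compound 4 is expected to be small, about a number no higher from compound 3 to compound 4 (the limit leaves the size open). Compound 4 is therefore estimated at 100 ug/mL, most likely reported only as a limit, in a range from 50 ug/mL to 200 ug/mL.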

Compound 4, half-maximal cytotoxic concentration: > 100 ug/mL
Compound 4: a limit, no number (the forecaster's own chance of this, stated with the estimate: 85%); the middle value lies on the limit itself.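

No step can be read between compound 3 and compound 4, as both results are limits rather than numbers: the limit of > 100 ug/mL in this assay, at which 4 of the 4 values shown sit. The compounds shown leave open how much of each is actually tolerated in this assay, and so whether any of these structural changes matters.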